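Lengthening the acyl group of compound 3

The source may report more compounds than this note shows. Statements on the series, on what has been measured and on what is new or still open speak of the compounds shown alone.

In a functional assay on MCF7 cells (Homo sapiens) for antiproliferative activity, read by sulforhodamine B assay, with a stated time of 48 h (on this read-out higher numbers stand for weaker inhibition and lower numbers for stronger inhibition), compound 3 `COc1cc(NC(C)CCCNC(C)=O)c2ncccc2c1` gives 57300 nM and compound 1 `COc1cc(NC(C)CCCN2C(=O)[C@H](C)NC2(C)C)c2ncccc2c1` gives 42300 nM, two values within the scatter of each other. Compound 2 `COc1cc(NC(C)CCCN2C(=O)CN(C(C)=O)C2(C)C)c2ncccc2c1` reaches only a limit, > 100000 nM. Compound 4 `COc1cc(NC(C)CCCNC(=O)C2CCCN2C(=O)[C@@H](C)N)c2ncccc2c1` departs from compound 3 by a single change, 1-((1-aminoethyl)carbonyl)pyrrolidin-2-yl in place of methyl on a carbonyl carbon. Among the compounds with values here, the only measured step that alters this end of the chain, a 1.4-fold higher number from compound 1 to compound 3 (0.13 log units; within the scatter), brings in acetamido and stays within the scatter. No step beyond the scatter is therefore expected in this assay, and the estimated step is a 1.1-fold lower number from compound 3 to compound 4 (0.06 log units; within the scatter). Compound 4 is expected to give 50000 nM, with an estimated range of 18000 nM to 100000 nM.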

Compound 4, half-maximal inhibitory concentration: 15000 nM
Compound 4: middle estimate off by 3.3-fold (0.52 log units), on the high side; the measured number lies below the stated range.
By their numbers in this assay, from the lowest: compound 4; then compounds 1 and 3 (each within the scatter of the next). At a limit, above all of these: compound 2.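

In this assay, 1-((1-aminoethyl)carbonyl)pyrrolidin-2-yl in place of methyl on a carbonyl carbon gives a 3.8-fold lower number from compound 3 to compound 4 (0.58 log units; beyond the scatter). Within the data shown here, the earlier change at this end of the chain, a 1.4-fold higher number from compound 1 to compound 3 (0.13 log units; within the scatter), did not separate its two compounds, so this is the first indication that the group at this place can shift the number. Nothing measured here accounts for the step.

As far as these compounds go, it remains open whether pyrrolidin-2-yl without its acyl group, or a simple aminomethyl group on the same carbonyl carbon, would produce a similar shift.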